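Oxidising the thioether: methylsulfonyl on the anilino-type ring

A few compounds are considered here, and "the series" means these few. Any claim that something is new, unique, unknown or untested is made for them only; others in the source may bear on it.

Compound 1, `COc1ccccc1CNc1ncnn1-c1cccc(Cl)c1Cl`: 57.5 nM
Compound 2, `CCOc1ccccc1CNc1ncnn1-c1cccc(Cl)c1Cl`: 45.7 nM
Compound 3, `CSc1ccccc1CNc1ncnn1-c1cccc(Cl)c1Cl`: 49 nM

Of the compounds shown here, three sharing one core have been measured in a functional assay for antagonist activity at P2X purinoceptor 7 (Homo sapiens), read by FLIPR and calcium flux; on this read-out higher numbers stand for weaker inhibition and lower numbers for stronger inhibition. Compound 3 sits second highest of the three numbers, yet its nearest neighbour is compound 2, at a 1.1-fold higher number from compound 2 to compound 3 (0.03 log units; within the scatter), and its most distant is compound 1, at a 1.2-fold lower number from compound 1 to compound 3 (0.07 log units; within the scatter). The third step, a 1.3-fold lower number from compound 1 to compound 2 (0.10 log units; within the scatter), is likewise within the scatter. In short, swapping methoxy, ethoxy and methylsulfanyl on this ring moves nothing that can be told apart from repeat measurement.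

Compound 4, `CS(=O)(=O)c1ccccc1CNc1ncnn1-c1cccc(Cl)c1Cl`, is not yet measured. It differs from compound 3 by methylsulfonyl in place of methylsulfanyl on an aromatic carbon, on an aromatic carbon of a six-membered aromatic ring of carbon only, ortho to a large group. Going by the values given here, none of the measured steps covers this change; they only show that this position has tolerated three small groups without a detectable shift. Among the compounds with values here, with no direct precedent, the estimate for compound 4 is 120 nM, with a range from 40 nM to 500 nM, meaning an expected step of a 2.4-fold higher number from compound 3 to compound 4 (0.39 log units; beyond the scatter) that is likely a modest weakening but could also be no change beyond the scatter.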

Compound 4, half-maximal inhibitory concentration: 20 nM
Compound 4: the middle estimate sits 6.0-fold (0.78 log units) above what was measured, and the stated range ends above it.
By their numbers in this assay, from the lowest: compound 4; then compounds 2, 3 and 1 (each within the scatter of the next).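

In this assay this position on the ring turns out to respond to the group it carries: methoxy, ethoxy and methylsulfanyl could not be told apart, but methylsulfonyl stands clear of all three, with a 2.5-fold lower number from compound 3 to compound 4 (0.39 log units; beyond the scatter) and a 2.3-fold lower number from compound 2 to compound 4 (0.36 log units; beyond the scatter) and also a 2.9-fold lower number from compound 1 to compound 4 (0.46 log units; beyond the scatter) as the steps. These steps are modest, yet all three point the same way, so this place accepts a larger group with two double bonds outside aromatic rings and gains from it. Nothing available here explains why this group gives the lower number.

On these data alone, whether a methylsulfinyl group, a sulfonamide or a longer chain on the sulfonyl sulfur would keep this gain remains open. So does whether methylsulfonyl would give the same step on a different core.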